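Trifluoromethyl for methoxy on the aryl amine of the shared core

The compounds below may be only part of what the source reports. "The series", "measured", "known", "first", "only" and "open" are said of these compounds alone.

Measured so far:
compound 1 `COc1cccc(Nc2nc3nonc3nc2Nc2ccccc2F)c1`: 830 nM
compound 2 `COc1ccc(Nc2nc3nonc3nc2Nc2ccccc2F)cc1`: 1600 nM

Both compounds were run in an assay on mitochondria from L6 cells (Rattus norvegicus) for activation, with a stated time of 90 min; a lower number here means that less compound is needed, a higher number that more compound is needed for the effect. Compound 1 gives 830 nM and compound 2 gives 1600 nM; the step of a 1.9-fold higher number from compound 1 to compound 2 (0.29 log units; within the scatter) lies within the scatter, so compound 2 shows the larger of the two numbers without any real separation from compound 1. Compound 3 `Fc1ccccc1Nc1nc2nonc2nc1Nc1ccc(C(F)(F)F)cc1` differs from compound 2 by trifluoromethyl in place of methoxy on an aromatic carbon. Among the measured compounds shown here, no measured step bears on this exchange; the only step at hand moves the methoxy to another position. Accordingly no step beyond the scatter is expected in this assay, and the estimate is no change at the digits printed from compound 2 to compound 3 (within the scatter). Compound 3 is expected at 1600 nM, in a range from 500 nM to 5000 nM.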

Compound 3, half-maximal effective concentration: 270 nM
Compound 3: the middle estimate sits 5.9-fold (0.77 log units) above what was measured; the measured number lies below the stated range.
By their numbers in this assay, from the lowest: compound 3; then compounds 1 and 2 (each within the scatter of the next).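

In this assay, the group on this aromatic carbon, para to a large group, clearly counts: trifluoromethyl in place of methoxy gives a 5.9-fold lower number from compound 2 to compound 3 (0.77 log units; beyond the scatter). Among the compounds shown here, the earlier change, which only moved the methoxy, gave a 1.9-fold higher number from compound 1 to compound 2 (0.29 log units; within the scatter), so this exchange is the first to reach beyond the scatter. No measurement at hand accounts for the step.

Going by these compounds, whether a nitrile, a chlorine atom or an amine on this carbon would behave like trifluoromethyl remains open. Also open, on these data alone, is how trifluoromethyl would fare where compound 1 carries its methoxy.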